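Cytotoxicity in the series: step from compound 3 to compound 4

This account rests on a few compounds, and the source may have more. Where it says the series, first, only, none or still open, it means among the compounds named here.

The three measured compounds share one core and differ in the aryl group on it. Compound 1 `CN(C)CCCCOC(=O)Nc1ccc(Cn2nc(-c3ccncc3)c3ccccc3c2=O)cc1` carries pyridin-4-yl and gives 62700 nM in an ADME assay on Huh-7 cells (Homo sapiens) for cytotoxicity, read by MTT assay, with a stated time of 48 h; on this read-out lower numbers stand for higher toxicity in this test and higher numbers for lower toxicity in this test. Compound 2 `CN(C)CCCCOC(=O)Nc1ccc(Cn2nc(-c3ccc(C(F)(F)F)cc3)c3ccccc3c2=O)cc1` carries 4-(trifluoromethyl)phenyl and gives 3360 nM; compound 3 `CN(C)CCCCOC(=O)Nc1ccc(Cn2nc(-c3cccc(C(F)(F)F)c3)c3ccccc3c2=O)cc1` carries 3-(trifluoromethyl)phenyl and gives 11600 nM. The steps are a 19-fold lower number from compound 1 to compound 2 (1.27 log units; beyond the scatter), a 5.4-fold lower number from compound 1 to compound 3 (0.73 log units; beyond the scatter) and a 3.5-fold higher number from compound 2 to compound 3 (0.54 log units; beyond the scatter). Compound 3 thus stands second highest of the three numbers, nearer to compound 2 than to compound 1.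

Compound 4 `CN(C)CCCCOC(=O)Nc1ccc(Cn2nc(-c3ccccc3C#N)c3ccccc3c2=O)cc1` is not yet measured. It differs from compound 3 by 2-cyanophenyl in place of 3-(trifluoromethyl)phenyl on an aromatic carbon. Within the data shown here, no measured step swaps a trifluoromethylphenyl for a cyanophenyl, so the only bearing comes from compound 1, whose pyridin-4-yl also holds a hydrogen-bond acceptor and whose number lies above that of compound 3 by a 5.4-fold lower number from compound 1 to compound 3 (0.73 log units; beyond the scatter). On that basis a modest step upward is expected for compound 4, namely a 2.2-fold higher number from compound 3 to compound 4 (0.33 log units; beyond the scatter), with the number for compound 4 estimated at 25000 nM within 8000 nM to 75000 nM.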

Compound 4, half-maximal cytotoxic concentration: 90700 nM
Compound 4: middle estimate off by 3.6-fold (0.56 log units), on the low side; measured number above the stated range.
By their numbers in this assay, from the lowest: compound 2; then compound 3; then compounds 1 and 4 (each within the scatter of the next).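

In this assay, 2-cyanophenyl at this aromatic carbon next to the ring nitrogen gives a 7.8-fold higher number from compound 3 to compound 4 (0.89 log units; beyond the scatter) and a 27-fold higher number from compound 2 to compound 4 (1.43 log units; beyond the scatter), so both trifluoromethylphenyl compounds lie well under it. Against pyridin-4-yl the change gives a 1.4-fold higher number from compound 1 to compound 4 (0.16 log units; within the scatter), so two aryl groups with different ring atoms and different substitution read alike here, and the low numbers in this set belong to compound 2 and compound 3 alone. Nothing at hand explains this separation.

The step to compound 4 changes both the substituent and its place on the phenyl ring, and these compounds cannot separate the two. As far as these compounds go, whether an unsubstituted phenyl, or a phenyl carrying an amine or a carboxylic acid, would read with compound 1 and compound 4 or with compound 2 and compound 3 remains open.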